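Removing One Methyl From a Growth Inhibitor

This account rests on a few compounds, and the source may have more. Where it says the series, first, only, none or still open, it means among the compounds named here.

Going by the values given here, only two compounds have been tested so far, both in a functional assay on KB cells (Homo sapiens) for inhibition, read by sulforhodamine B assay, with a stated time of 72 h; a lower number here means a stronger inhibitor of growth, a higher number a weaker inhibitor of growth. Compound 1 `CCOC(=O)/C=C/c1ccncc1-c1ccc2[nH]ccc2c1` gives > 10000 nM, which is a limit of the assay and not a number. Among the compounds with values here, compound 2 `CNC(=O)/C=C/c1ccncc1-c1ccc2c(ccn2C)c1` gives 7080 nM, so it holds the only actual number available, and that number offers the sole firm reference point here.

The next compound, compound 3 `CNC(=O)/C=C/c1ccncc1-c1ccc2[nH]ccc2c1`, departs from compound 2 in one place, with hydrogen in place of methyl on an aromatic nitrogen. Within the data shown here, no measured pair shows what this kind of change does in this assay, so the expectation has to stay modest. A change no larger than the usual scatter of repeated measurements is expected, with no firm direction, and the starting point is compound 2 at 7080 nM. Compound 3 may also turn out to give only a limit rather than a number. The estimated change is a 1.2-fold lower number from compound 2 to compound 3 (0.07 log units; within the scatter). Compound 3 is expected at 6000 nM, with an estimated range from 3000 nM to 14000 nM.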

Compound 3, concentration for 50% growth inhibition: > 10000 nM
Compound 3: a limit, no number (the forecaster's own chance of this, stated with the estimate: 35%); middle value at least 1.6-fold (0.22 log units) from the limit.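

In this assay, going by these compounds alone, the first measured pair for hydrogen in place of methyl on an aromatic nitrogen gives an at least 1.4-fold higher number from compound 2 to compound 3 (0.14 log units; that floor lies within the scatter). The result for compound 3 is a limit of the assay and not a number, and the true step may be as small as that floor or considerably larger. Within the data shown here, with the methyl gone, compound 2 remains the only compound here with an actual number, and the size of the step cannot be pinned down because the reading stops at the edge of what the assay reports: the limit of > 10000 nM in this assay, at which 2 of the 3 values shown sit.

Compound 1 and compound 3 both carry limits, and the step of methylamino in place of ethoxy on a carbonyl carbon cannot be read from them. Still open, from the compounds shown here alone, is what a longer chain such as propyl, or a chain ending in an amine or a carboxylic acid, would do on that aromatic nitrogen of the five-membered ring, and whether any such group would give a number lower than that of compound 2.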